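The source may report more compounds than this note shows. Statements on the series, on what has been measured and on what is new or still open speak of the compounds shown alone.

Three compounds of a shared core were measured in a functional assay on A549 cells (Homo sapiens) for cytotoxicity, read by MTT assay, with a stated time of 72 h; on this read-out higher numbers stand for an effect only at larger amounts of compound and lower numbers for an effect already at smaller amounts:

compound 1 `CCS[C@@H]1[C@H](SCC)[C@@H](Cn2cc(-c3ccc(F)cc3)nn2)O[C@H]1n1ccc(=O)[nH]c1=O`, 22900 nM
compound 2 `CCS[C@@H]1[C@H](SCC)[C@@H](Cn2cc(-c3ccc(OC)cc3)nn2)O[C@H]1n1ccc(=O)[nH]c1=O`, 16800 nM
compound 3 `CCOC(=O)c1cn(C[C@H]2O[C@@H](n3ccc(=O)[nH]c3=O)[C@H](SCC)[C@@H]2SCC)nn1`, >= 100000 nM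

The value of compound 3 in this assay is a limit of the assay and not a number (the limit of >= 100000 nM in this assay, at which 1 of the 3 values shown sits). Among the two numbers shown, compound 1 stands highest, with compound 2 nearest: a 1.4-fold lower number from compound 1 to compound 2 (0.13 log units; within the scatter). The two steps that change the group on the triazole are larger: an at least 4.3-fold higher number from compound 1 to compound 3 (0.64 log units; beyond the scatter) and an at least 5.9-fold higher number from compound 2 to compound 3 (0.77 log units; beyond the scatter).

Compound 4 `CCS[C@@H]1[C@H](SCC)[C@@H](Cn2cc(-c3ccc(F)cc3)nn2)O[C@H]1n1cc(C)c(=O)[nH]c1=O` differs from compound 1 elsewhere, on the uracil ring: methyl in place of hydrogen on an aromatic carbon. For the measured compounds named here, none of the measured steps touches this position; all of them change the group on the triazole while the uracil is kept. The measured steps therefore offer no direct guide, and a methyl of one heavy atom at this place is expected to give no step beyond the scatter in this assay. The estimate for compound 4 is accordingly 21000 nM, between 8000 nM and 60000 nM, a step of a 1.1-fold lower number from compound 1 to compound 4 (0.04 log units; within the scatter) that is expected to lie within the scatter.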

Compound 4, half-maximal effective concentration: >= 100000 nM
Compound 4 ended at the assay's limit; the forecaster's own chance of this, stated with the estimate: 20%; middle value at least 4.7-fold (0.67 log units) away from the limit.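

For the compounds shown here, the position on the uracil ring, which no earlier step touched, proves sensitive: in this assay, methyl in place of hydrogen gives an at least 4.3-fold higher number from compound 1 to compound 4 (0.64 log units; beyond the scatter). The value of compound 4, >= 100000 nM, is a limit of the assay and not a number. Among the earlier compounds, only compound 3, with its changed group on the triazole, stood at this limit, and now a change of a single heavy atom on the uracil ring reaches it too: the limit of >= 100000 nM in this assay, at which 2 of the 4 values shown sit.

Only hydrogen and methyl are shown on this carbon, so it remains open how an ethyl group, a fluorine atom or an amine there would read. On these data alone, it also remains open whether methyl at this position would give a comparable step with the 4-methoxyphenyl group of compound 2 on the triazole.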